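A few compounds are considered here, and "the series" means these few. Any claim that something is new, unique, unknown or untested is made for them only; others in the source may bear on it.

Of the compounds shown here, three sharing one core have been measured in an ADME assay on L6 cells (Rattus norvegicus) for cytotoxicity, read by resazurin assay, with a stated time of 72 h; a higher number here means a weaker inhibitor, a lower number a stronger inhibitor. Compound 1 `Cc1ccc(C(O)(c2ccc(Cl)cc2)c2cccnc2)cc1` gives 61000 nM, compound 2 `OC(c1ccc(Cl)cc1)(c1cccnc1)c1cccc(F)c1` gives 66000 nM, and compound 3 `Cc1ccccc1C(O)(c1ccc(Cl)cc1)c1cccnc1` gives 82000 nM. Compound 2 thus stands among three values that all lie within the scatter of one another, so no real order can be read from them.

Compound 4 `CC(C)Oc1cccc(C(O)(c2ccc(Cl)cc2)c2cccnc2)c1` has not been measured yet. It keeps the core of compound 2 and alters one group: isopropoxy in place of fluoro on an aromatic carbon. Here, isopropoxy takes the place of fluoro on an aromatic carbon, meta to a large group.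

The measured steps that bear on this change all swap one aromatic group on the shared core. They are a 1.1-fold higher number from compound 1 to compound 2 (0.03 log units; within the scatter), a 1.3-fold higher number from compound 1 to compound 3 (0.13 log units; within the scatter) and a 1.2-fold higher number from compound 2 to compound 3 (0.09 log units; within the scatter). Each of these is small and within the scatter. None of them introduces an isopropoxy, so the data hold no direct test of this group, and the range must stay wide.

No step beyond the scatter is therefore expected in this assay. The estimated step is a 1.1-fold lower number from compound 2 to compound 4 (0.04 log units; within the scatter). For compound 4 the expected value is 60000 nM, with an estimated range from 30000 nM to 100000 nM.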

Compound 4, half-maximal inhibitory concentration: 67600 nM
Compound 4: the middle estimate sits 1.1-fold (0.05 log units) below what was measured; the range from low to high includes it.
By their numbers in this assay, from the lowest: compounds 1, 2, 4 and 3 (each within the scatter of the next).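

In this assay, putting isopropoxy in place of fluoro on an aromatic carbon, meta to a large group, gives a 1.0-fold higher number from compound 2 to compound 4 (0.01 log units; within the scatter) and so leaves the number within the scatter. The earlier compounds shown here differed only in a fluoro or a methyl group on this aromatic ring, so they could not show what a clearly larger group does; here 4 heavy atoms, including 1 hydrogen-bond acceptor, replace 1 heavy atom with no acceptor, and still no real step appears. No measurement available here accounts for this result.

Going by these compounds, it remains open whether an amine, a carboxylic acid or a longer chain on this same aromatic carbon would also stay within the scatter or would produce a clear step. On these data alone, with all four compounds lying within the scatter of the next, it also remains open which change to this aromatic ring, if any, would shift the number in this assay by more than the usual variation between repeated measurements.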